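This account rests on a few compounds, and the source may have more. Where it says the series, first, only, none or still open, it means among the compounds named here.

Measured so far in an ADME assay on HEL cells (Homo sapiens) for cytotoxicity, with a stated time of 3 days; a higher number here means that more compound is tolerated, a lower number that less compound is tolerated:
Compound 1 `C=Cc1ccc(-c2cc(C)c3ncc(CSCCc4ccccc4)n3c2)cc1` gives 20 ug/mL.
Compound 2 `Cc1cc(N2CCCC2)cn2c(CSCCc3ccccc3)cnc12` gives 20 ug/mL.
Compound 3 `Cc1cc(N2CCCC2=O)cn2c(CSCCc3ccccc3)cnc12` reaches only a limit of the assay, > 100 ug/mL.

Compound 3 thus stands at the top of what the assay can report (the limit of > 100 ug/mL in this assay, at which 1 of the 3 values shown sits), with no exact number known. Compound 4 `Cc1cc(Sc2ccc(N)cc2)cn2c(CSCCc3ccccc3)cnc12` differs from it in one place: (4-aminophenyl)sulfanyl in place of 2-oxopyrrolidin-1-yl on an aromatic carbon. Among the compounds with values here, two measured steps bear on this. Both an at least 5.0-fold higher number from compound 1 to compound 3 (0.69 log units; beyond the scatter) and an at least 5.0-fold higher number from compound 2 to compound 3 (0.69 log units; beyond the scatter) show that bringing in 2-oxopyrrolidin-1-yl raised the number; compound 4 removes that group again, so a step back down in this assay is expected, of about an at least 5.0-fold lower number from compound 3 to compound 4 (0.69 log units; beyond the scatter). Compound 4 is therefore estimated at 20 ug/mL, within 7 ug/mL to 100 ug/mL.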

Compound 4, minimum cytotoxic concentration: 20 ug/mL
The estimate for compound 4 equals the measured number at the digits printed; measured number inside the range.
By their numbers in this assay, from the lowest: compounds 1, 2 and 4 (each within the scatter of the next). At a limit, above all of these: compound 3.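

In this assay, (4-aminophenyl)sulfanyl in place of 2-oxopyrrolidin-1-yl gives an at least 5.0-fold lower number from compound 3 to compound 4 (0.69 log units; beyond the scatter), while the other two comparisons show no change at the digits printed from compound 2 to compound 4 (within the scatter) and no change at the digits printed from compound 1 to compound 4 (within the scatter). Compound 3 stands at a limit and not at an exact number: the limit of > 100 ug/mL in this assay, at which 1 of the 4 values shown sits. Among these four compounds, 4-vinylphenyl, pyrrolidin-1-yl and (4-aminophenyl)sulfanyl read alike at this position, and only 2-oxopyrrolidin-1-yl stands apart.

From the compounds shown here alone, it remains open whether the carbonyl of 2-oxopyrrolidin-1-yl or its ring accounts for this difference. An open-chain amide or a piperidin-2-one at this position could help separate the two.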